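The compounds below may be only part of what the source reports. "The series", "measured", "known", "first", "only" and "open" are said of these compounds alone.

Going by the values given here, in a functional assay on HL-60 cells (Homo sapiens) for inhibition, read by CCK-8 assay, with a stated time of 48 h (a higher number here means a weaker inhibitor, a lower number a stronger inhibitor), compound 3 `O=C(Nc1ccc([N+](=O)[O-])cc1)N1CCN(S(=O)(=O)c2sccc2-c2ccccc2Oc2ccc(O)c(O)c2)CC1` gives 4900 nM, the only actual number so far. Compound 1 `COc1ccc(Oc2ccccc2-c2ccsc2S(=O)(=O)N2CCN(C(=S)Nc3ccc([N+](=O)[O-])cc3)CC2)cc1OC` reports only a limit, > 50000 nM. Compound 2 `COc1ccc(Oc2ccccc2-c2ccsc2S(=O)(=O)N2CCN(C(=O)Nc3ccc([N+](=O)[O-])cc3)CC2)cc1OC` also reports only a limit, > 50000 nM. The move to compound 4 `O=[N+]([O-])c1ccc(NC(=S)N2CCN(S(=O)(=O)c3sccc3-c3ccccc3Oc3ccc(O)c(O)c3)CC2)cc1` keeps the 3,4-dihydroxyphenyl and changes one place: a group of 12 heavy atoms (7 carbon, 2 nitrogen, 2 oxygen, 1 sulfur; one six-membered aromatic ring of carbon only) in place of a group of 12 heavy atoms (7 carbon, 2 nitrogen, 3 oxygen; one six-membered aromatic ring of carbon only), on an amine nitrogen in a ring. The same exchange, run the other way, appears in a step that the two limits leave unreadable from compound 1 to compound 2, which gives no size. The other measured step, an at least 10-fold lower number from compound 2 to compound 3 (1.00 log units; beyond the scatter), lies at a different place, and compound 4 retains its outcome. With no readable size for this exchange, no step beyond the scatter is expected in this assay. The estimated step is a 1.2-fold lower number from compound 3 to compound 4 (0.09 log units; within the scatter). Compound 4 is expected at 4000 nM, with an estimated range of 1200 nM to 15000 nM.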

Compound 4, half-maximal inhibitory concentration: 5300 nM
For compound 4 the middle estimate is 1.3-fold (0.12 log units) below the measured one; the range from low to high includes it.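

With the 3,4-dihydroxyphenyl in place, the exchange on the amine nitrogen in a ring now has a readable size in this assay: a 1.1-fold higher number from compound 3 to compound 4 (0.03 log units; within the scatter). The gain from 3,4-dihydroxyphenyl in place of 3,4-dimethoxyphenyl also recurs with the sulfur-bearing group, as an at least 9.4-fold lower number from compound 1 to compound 4 (0.97 log units; beyond the scatter), though compound 1 gives only a limit. The change thus holds with either group on that nitrogen: the same change on two cores in this assay, an at least 10-fold lower number (1.00 log units; beyond the scatter) from compound 2 to compound 3 and an at least 9.4-fold lower number (0.97 log units; beyond the scatter) from compound 1 to compound 4; the limit leaves it open whether they differ.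

The compounds shown leave open what a carboxylic acid in place of the nitro group would give, and whether a single hydroxyl on that phenyl would suffice.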